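The compounds below may be only part of what the source reports. "The series", "measured", "known", "first", "only" and "open" are said of these compounds alone.

The shared core runs through three measured compounds and one not yet measured. Compound 1 `COc1ccc(NC2=CC(=O)c3c(nc4n3[C@H]3OC[C@@H](O)[C@H]3OC4)C2=O)cc1` and compound 2 `CCOc1ccc(NC2=CC(=O)c3c(nc4n3[C@H]3OC[C@@H](O)[C@H]3OC4)C2=O)cc1` carry an aryl amine, compound 3 `O=C1C(NC2CCCC2)=CC(=O)c2c1nc1n2[C@H]2OC[C@@H](O)[C@H]2OC1` a cyclopentylamino group, and compound 4 `CCCN(CCC)C1=CC(=O)c2c(nc3n2[C@H]2OC[C@@H](O)[C@H]2OC3)C1=O` a dipropylamino group at the same position. In a functional assay on ECa-109 cells for inhibition, with ECa-109 cell line (Homo sapiens) as the target, read by sulforhodamine B assay (a lower number here means a stronger inhibitor, a higher number a weaker inhibitor), compound 1 gives 3410 nM. In this assay compound 2 gives > 4000 nM, which is a limit of the assay and not a number. In this assay compound 3 gives > 16000 nM, again a limit and not a number. Compound 3 therefore stands at the weak end of what has been measured, marked only by the limit of > 16000 nM in this assay, at which 1 of the 3 values shown sits. The change from compound 3 to compound 4 is dipropylamino in place of cyclopentylamino on a double-bonded ring carbon. For the measured compounds named here, no measured step exchanges one alkyl amine for another; the nearest evidence is an at least 4.6-fold higher number from compound 1 to compound 3 (0.67 log units; beyond the scatter), and a step that the two limits leave unreadable from compound 2 to compound 3. Both leave the alkyl amine on the weak side, so compound 4 is expected to stay there, with a step that the limit leaves unreadable from compound 3 to compound 4 that is expected to fall within the scatter. The estimate for compound 4 in this assay is 20000 nM, expected to lie between 6000 nM and 60000 nM.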

Compound 4, half-maximal inhibitory concentration: > 16000 nM
Compound 4: no number, only a limit; the forecaster's own chance of this, stated with the estimate: 70%; the middle value does not contradict the limit.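

In this assay the dipropylamino group, with no ring and 0 hydrogen-bond donors, gives a limit of the assay and not a number, the same limit that the cyclopentylamino group gives: the limit of > 16000 nM in this assay, at which 2 of the 4 values shown sit. Set against the (4-methoxyphenyl)amino group, the change on the double-bonded ring carbon is an at least 4.6-fold higher number from compound 1 to compound 4 (0.67 log units; beyond the scatter), so a second alkyl amine now falls on the weak side of the series, where only compound 3 stood before. For the compounds shown here, the step between compound 3 and compound 4 cannot be read, as both ends are limits, and so the data show only that opening the ring and removing the hydrogen-bond donor does not bring the value under the limit.

As far as these compounds go, how far compound 3 and compound 4 lie beyond that limit stays open, as does any order between them. Also open, from the compounds shown here alone, is whether a smaller amine such as dimethylamino or a morpholine ring at this carbon would give a true number in this assay, or whether only an aryl amine such as that of compound 1 does so.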